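This account rests on a few compounds, and the source may have more. Where it says the series, first, only, none or still open, it means among the compounds named here.

Working notes on the series. The shared core is that of compound 1 `Nc1cc(N)c2nc(-c3ccccc3)c(Oc3ccc(Cl)c(Cl)c3)nc2c1`, which in a functional assay on K562 cells (Homo sapiens) for inhibition, read by sulforhodamine B assay, with a stated time of 48 h (on this read-out lower numbers stand for stronger inhibition of growth and higher numbers for weaker inhibition of growth), gives only a limit, < 100000 nM, and not a number. Compound 2 `Nc1cc(N)c2nc(-c3ccccc3)c(NCc3ccc(Cl)c(Cl)c3)nc2c1` carries the same core with a nitrogen linker; in this assay compound 2 gives 17800 nM. Going by the values given here, compound 2 thus stands as the only number in hand for this assay. The one further entry is a limit, (the limit of < 100000 nM in this assay, at which 1 of the 2 values shown sits). Compound 3 `COc1ccc(CNc2nc3cc(N)cc(N)c3nc2-c2ccccc2)cc1OC` is not yet measured in this assay and differs from compound 2 in one place: 3,4-dimethoxyphenyl in place of 3,4-dichlorophenyl on a saturated chain carbon bound to a nitrogen on an aromatic ring. Among the compounds with values here, no step between two measured compounds is on record for a change of this kind, so nothing in the data fixes its size. The expected step is a 1.4-fold higher number from compound 2 to compound 3 (0.15 log units; within the scatter), small, toward weaker growth inhibition, and hardly beyond the usual scatter. The estimate for compound 3 in this assay is 25000 nM, with a range from 8000 nM to 80000 nM.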

Compound 3, concentration for total growth inhibition: < 100000 nM
Compound 3 gave a limit, no number; the forecaster's own chance of this, stated with the estimate: 20%; the middle value does not contradict the limit.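

Compound 3 gives only a limit and not a number, so no step from compound 2 to compound 3 can be read in this assay: the limit of < 100000 nM in this assay, at which 2 of the 3 values shown sit.

The compounds shown leave open how large the effect on growth inhibition is of 3,4-dimethoxyphenyl in place of 3,4-dichlorophenyl, and in which direction it runs.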